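This account rests on a few compounds, and the source may have more. Where it says the series, first, only, none or still open, it means among the compounds named here.

Working notes on the series in a functional assay on SGC-7901 cells (Homo sapiens) for antiproliferative activity, read by MTT assay, with a stated time of 72 h; on this read-out higher numbers stand for weaker inhibition and lower numbers for stronger inhibition. Going by the values given here, compound 3 `COc1cc(-n2cnc3ccc(-c4cccc(O)c4)cc32)cc(OC)c1OC` gives 53 nM, the lowest of the three numbers measured so far. Compound 1 `COc1ccc(-c2ccc3ncn(-c4cc(OC)c(OC)c(OC)c4)c3c2)cc1F` gives 430 nM and compound 2 `COc1cc(-n2cnc3ccc(-c4ccc(C(F)(F)F)cc4)cc32)cc(OC)c1OC` gives 890 nM; the steps to compound 3 are an 8.1-fold lower number from compound 1 to compound 3 (0.91 log units; beyond the scatter) and a 17-fold lower number from compound 2 to compound 3 (1.23 log units; beyond the scatter), both beyond the scatter, and the step of a 2.1-fold higher number from compound 1 to compound 2 (0.32 log units; beyond the scatter) separates the two weaker compounds from each other.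

Compound 4 `COc1cc(-n2cnc3ccc(-c4ccc(O)cc4)cc32)cc(OC)c1OC` is the next in line. Its difference from compound 3: 4-hydroxyphenyl in place of 3-hydroxyphenyl on an aromatic carbon. None of the three measured steps tests this change, since all three swap one aryl group for another of different composition, whereas here the atoms are the same and only the arrangement differs. Among the compounds with values here, the measured steps show only that the 3-hydroxyphenyl compound sits well below the two others. Within the data shown here, with no step of this kind to lean on, a modest step in this assay is expected, more likely towards a higher number than a lower one, as a 2.8-fold higher number from compound 3 to compound 4 (0.45 log units; beyond the scatter). Compound 4 is therefore estimated at 150 nM, within a range from 45 nM to 500 nM.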

Compound 4, half-maximal inhibitory concentration: > 10000 nM
Compound 4 was reported as a limit (the forecaster's own chance of this, stated with the estimate: 3%); middle value at least 66-fold (1.82 log units) away from the limit.
By their numbers in this assay, from the lowest: compound 3; then compound 1; then compound 2. At a limit, above all of these: compound 4.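

In this assay, moving the hydroxy alone, with the atoms unchanged, gives an at least 180-fold higher number from compound 3 to compound 4 (2.27 log units; beyond the scatter), so this position responds sharply to the arrangement of the aryl group, which the earlier swaps could not show because each also changed its composition. A hydroxy on the aryl group is therefore not enough by itself for the low number of compound 3: the 4-hydroxyphenyl compound also lies past the two aryl compounds without hydroxy, with an at least 11-fold higher number from compound 2 to compound 4 (1.05 log units; beyond the scatter) and an at least 23-fold higher number from compound 1 to compound 4 (1.36 log units; beyond the scatter). The value of compound 4 is a limit of the assay and not a number, so all three steps are bounds: the limit of > 10000 nM in this assay, at which 1 of the 4 values shown sits.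

Going by these compounds, whether the low number of compound 3 needs the hydroxy itself stays open, and an amine or a carboxylic acid in its place on the same carbon would test this. On these data alone, the true size of the steps to compound 4 also stays open, with only a limit at hand.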